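A Sulfur-Free Chain Tested in the Rat

The source may hold more compounds than are shown below. What is called first, only, known or untested is meant among the compounds shown, and "the series" means these compounds.

Three compounds have so far been run in a functional assay on the whole organism with Rattus norvegicus as the target, at a dose of 100 mg/kg; on this read-out lower numbers stand for less inhibition and higher numbers for more inhibition at the one dose given (going by the name of the read-out). Compound 1 `CC/N=C(/NC#N)NCCCn1nc(-c2ccccc2)cc(C)c1=O` gives 23.5% in this assay, and compound 3 `O=c1ccc(-c2ccccc2)nn1CCCC/N=C(\S)Nc1ccc(S(=O)(=O)O)cc1` gives 25.1%. Compound 2 `CC/N=C(\S)NCCCCCCn1nc(-c2ccccc2)ccc1=O` gives -5.6% in this assay, the lowest of the three numbers; the nearest value is that of compound 1, which lies beyond the usual scatter above it, and the furthest is that of compound 3, also beyond the scatter above it.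

Compound 4 `C/N=C(/NC#N)NCCCCCn1nc(-c2ccccc2)ccc1=O` has not yet been measured in this assay. It differs from compound 2 in one place: a group of 7 heavy atoms (3 carbon, 4 nitrogen; no ring) in place of a group of 7 heavy atoms (4 carbon, 2 nitrogen, 1 sulfur; no ring), on a saturated chain carbon, five bonds along the chain from an aromatic nitrogen. For the measured compounds named here, no pair of measured compounds differs by this change alone, so nothing measured shows directly what this exchange does. Going by the values given here, what is known is that the group entering in compound 4 is of the same kind as the one carried by compound 1, which gives 23.5%, and that compound 3 gives 25.1%, while compound 2 with the sulfur-bearing group sits at the bottom. On that basis the step from compound 2 to compound 4 is expected to be upward, of a size near a number 20.6 percentage points higher from compound 2 to compound 4 (beyond the scatter) in this assay, though a result within the scatter of compound 2 cannot be excluded. Compound 4 is therefore estimated to give about 15% in this assay, within a range from -5% to 35%.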

Compound 4, a percentage reported as inhibition, in the whole organism at one dose (the size of the read-out at that dose, not a potency): 47.6%
For compound 4 the middle estimate is 32.6 percentage points below the measured one; measured number outside the range, above it.
By their numbers in this assay, from the lowest: compound 2; then compounds 1 and 3 (each within the scatter of the next); then compound 4.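

In this assay, the exchange on a saturated chain carbon, five bonds along the chain from an aromatic nitrogen, now has a direct reading: putting the group of 7 heavy atoms (3 carbon, 4 nitrogen; no ring) in place of the group of 7 heavy atoms (4 carbon, 2 nitrogen, 1 sulfur; no ring) gives a number 53.2 percentage points higher from compound 2 to compound 4 (beyond the scatter). This large step comes with a modest difference in what is counted, since both groups have 7 heavy atoms, no ring, 2 hydrogen-bond donors and no net charge, while the entering group has no sulfur, adds 1 triple bond and has 2 hydrogen-bond acceptors rather than 1. No measurement bears on why the number moves so far at this position.

The compounds shown leave open which part of the entering group carries the step, for instance whether a urea with a carbonyl oxygen in place of the nitrile-bearing nitrogen would give a similar number. They also leave open whether a plain amine or a carboxylic acid at this chain carbon would do the same, and whether the step holds on a longer chain.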